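From pyridin-3-yl to pyridin-4-yl on the shared core

This account rests on a few compounds, and the source may have more. Where it says the series, first, only, none or still open, it means among the compounds named here.

Of the compounds shown here, three have been measured in a functional assay on colon cells (Homo sapiens) for antiproliferative activity (on this read-out lower numbers stand for stronger inhibition of growth and higher numbers for weaker inhibition of growth), so far.

- Compound 1 `Cc1cn2c(/C=N/NC(=N)N)c(-c3ccncc3)nc2s1` gives 15800 nM
- Compound 2 `N=C(N)N/N=C/c1c(-c2ccccn2)nc2sc(Cl)cn12` gives 7080 nM
- Compound 3 `N=C(N)N/N=C/c1c(-c2cccnc2)nc2sc(Cl)cn12` gives 8510 nM

On these numbers, compound 3 lies within the scatter of both compound 2 and compound 1. Compound 4 `N=C(N)N/N=C/c1c(-c2ccncc2)nc2sc(Cl)cn12` differs from compound 3 in one place. The change is pyridin-4-yl in place of pyridin-3-yl on an aromatic carbon in words pyridin-4-yl in place of pyridin-3-yl on an aromatic carbon. Among the measured compounds shown here, the one measured step that bears on it, a 1.2-fold higher number from compound 2 to compound 3 (0.08 log units; within the scatter) (pyridin-3-yl in place of pyridin-2-yl), lies within the scatter. No step beyond the scatter is therefore expected in this assay in either direction. The expected step is a 1.1-fold lower number from compound 3 to compound 4 (0.03 log units; within the scatter) and it is estimated to stay within the scatter. Compound 4 is estimated at 8000 nM with an expected range from 4000 nM to 16000 nM in this read-out.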

Compound 4, concentration for 50% growth inhibition: 8130 nM
Compound 4: middle estimate off by 1.0-fold (0.01 log units), on the low side; the measured number falls inside the stated range.
By their numbers in this assay, from the lowest: compounds 2, 4, 3 and 1 (each within the scatter of the next, the first and the last beyond it).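

In this assay, the pyridin-4-yl group reads the same as pyridin-3-yl (a 1.0-fold lower number from compound 3 to compound 4 (0.02 log units; within the scatter)) and pyridin-2-yl (a 1.1-fold higher number from compound 2 to compound 4 (0.06 log units; within the scatter)), so all three pyridine attachments on the chloro-bearing shared core now lie within the scatter of one another. The same compound gives the first single-place view of the other substituent, since chloro in place of methyl also stays within the scatter (a 1.9-fold lower number from compound 1 to compound 4 (0.29 log units; within the scatter)). Nothing available explains this flat response. Still open, going by these compounds, is whether a phenyl ring or a morpholine at the pyridine's place would move the read-out beyond the scatter, and whether an amine or a carboxylic acid in place of chloro would do so.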